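Isobutoxy in place of methoxy on the cinnamoyl enol series

The source may report more compounds than this note shows. Statements on the series, on what has been measured and on what is new or still open speak of the compounds shown alone.

Compound 1 `CCCC1=C(OC)C(CCC)(CCC)C(=O)/C(=C(O)\C=C\c2ccccc2)C1=O` carries a methoxy on the shared core and a plain phenyl on the cinnamoyl arm. Within the data shown here, in a functional assay on HepG2 cells (Homo sapiens) for antiproliferative activity, read by sulforhodamine B assay, with a stated time of 3 days (on this read-out higher numbers stand for an effect only at larger amounts of compound and lower numbers for an effect already at smaller amounts), compound 1 stands at "not determined" (no result reported); the only number comes from its iodophenyl analogue, compound 2 `CCCC1=C(OC)C(CCC)(CCC)C(=O)/C(=C(O)\C=C\c2ccc(I)cc2)C1=O`, which in this assay gives 2.4 uM. Among the measured compounds shown here, that value places the core itself in the low micromolar region, but it says nothing about the alkoxy group, which is the only part that changes here.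

Compound 3 `CCCC1=C(OCC(C)C)C(CCC)(CCC)C(=O)/C(=C(O)\C=C\c2ccccc2)C1=O` is the isobutoxy analogue of compound 1. The change is isopropyl in place of hydrogen on a saturated chain carbon bound to an oxygen on an unsaturated carbon. For the measured compounds named here, no measured pair tracks this change, so its size in this assay is unknown; the expectation is a step no larger than the usual scatter, in either direction, with compound 2 as the sole reference point for the level.

On that basis compound 3 is estimated at 4 uM in this assay, within 1 uM to 16 uM, an expectation resting on compound 2 and its 2.4 uM rather than on any direct comparison.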

Compound 3, concentration for half-maximal effect: 13.4 uM
Compound 3: the middle estimate sits 3.4-fold (0.53 log units) below what was measured; measured number inside the range.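

No new step can be read: in this assay compound 1 stands at "not determined" (no result reported) and compound 3 gives 13.4 uM, while compound 2 differs from compound 3 in two places. The compounds shown leave open how methoxy to isobutoxy alters the value in this assay on the shared core. No supporting data bear on this result.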